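Aryl ester change from compound 2 to compound 3

This account rests on a few compounds, and the source may have more. Where it says the series, first, only, none or still open, it means among the compounds named here.

Measured so far:
- compound 1 `CC1=CC[C@H]2[C@H](CC[C@]2(C)O)C(C)(C)[C@@H]1CC[C@H]1[C@]2(C)CC[C@H](OC(=O)c3ccc(Cl)c(Cl)c3)C(C)(C)O[C@H]2CC[C@@]1(C)O`: 11900 nM
- compound 2 `CC1=CC[C@H]2[C@H](CC[C@]2(C)O)C(C)(C)[C@@H]1CC[C@H]1[C@]2(C)CC[C@H](OC(=O)c3ccccc3C(F)(F)F)C(C)(C)O[C@H]2CC[C@@]1(C)O`: 19200 nM

Both compounds were tested in a functional assay on MCF7 cells (Homo sapiens) for antiproliferative activity, read by MTT assay, with a stated time of 72 h; on this read-out higher numbers stand for weaker inhibition and lower numbers for stronger inhibition. For the measured compounds named here, compound 2 stands within the scatter of compound 1, the only other measured compound, so the pair gives no ranking. Still unmeasured is compound 3 `CC1=CC[C@H]2[C@H](CC[C@]2(C)O)C(C)(C)[C@@H]1CC[C@H]1[C@]2(C)CC[C@H](OC(=O)c3ccc(C(F)(F)F)cc3F)C(C)(C)O[C@H]2CC[C@@]1(C)O`, which keeps the shared core and differs only in the aryl group on the carbonyl carbon: 2-fluoro-4-(trifluoromethyl)phenyl in place of 2-(trifluoromethyl)phenyl on a carbonyl carbon. In words, 2-fluoro-4-(trifluoromethyl)phenyl comes in place of 2-(trifluoromethyl)phenyl. Going by the values given here, one measured step bears on this change: a 1.6-fold higher number from compound 1 to compound 2 (0.21 log units; within the scatter). It is also an exchange of the aryl group on that carbonyl carbon, and it lies within the scatter. Among the compounds with values here, no measured compound carries the entering group, so the evidence is thin. On that single step, no change beyond the scatter is expected in this assay, and no direction can be claimed with confidence. The expected step is a 1.2-fold lower number from compound 2 to compound 3 (0.08 log units; within the scatter). Compound 3 is estimated at 16000 nM, with an expected range from 8000 nM to 32000 nM.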

Compound 3, half-maximal inhibitory concentration: > 50000 nM
Compound 3: only a limit was reported (the forecaster's own chance of this, stated with the estimate: 10%); middle value at least 3.1-fold (0.49 log units) from the limit.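

In this assay compound 3 is reported as > 50000 nM, which is a limit of the assay and not a number. The aryl group on the carbonyl carbon therefore turns out not to be indifferent: 2-fluoro-4-(trifluoromethyl)phenyl gives an at least 2.6-fold higher number from compound 2 to compound 3 (0.41 log units; beyond the scatter) and an at least 4.2-fold higher number from compound 1 to compound 3 (0.62 log units; beyond the scatter), whereas the exchange between the two earlier aryl groups gave only a 1.6-fold higher number from compound 1 to compound 2 (0.21 log units; within the scatter). The inhibition is weaker with this group than with either earlier group, but only the lower end of each step is fixed and the true size stays unknown, with the reading resting on a single compound at the limit: the limit of > 50000 nM in this assay, at which 1 of the 3 values shown sits.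

Compound 3 differs from compound 2 in both the fluorine and the place of the trifluoromethyl group, so the shift cannot be assigned to either part, and a plain 2-fluorophenyl or 4-(trifluoromethyl)phenyl ester on the shared core would separate the two. As far as these compounds go, whether an aryl group carrying an amine or a carboxylic acid would move the number lower in this assay also remains open.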